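This account rests on a few compounds, and the source may have more. Where it says the series, first, only, none or still open, it means among the compounds named here.

Compound 1 `COc1nc(N)nc2c1c(-c1ccccc1)cn2[C@@H]1O[C@H](CO)[C@@H](O)[C@H]1O` gives > 20000 nM in a functional assay on CEM-DNR-bulk cells (Homo sapiens), read by MTT assay, with a stated time of 72 h (on this read-out lower numbers stand for stronger inhibition and higher numbers for weaker inhibition), a limit of the assay rather than a number.
Compound 2 `COc1ncnc2c1c(-c1ccccc1)cn2[C@@H]1O[C@H](CO)[C@@H](O)[C@H]1O` gives > 20000 nM in this assay, again a limit.
Compound 3 `O=c1[nH]cnc2c1c(-c1cc3ccccc3o1)cn2[C@@H]1O[C@H](CO)[C@@H](O)[C@H]1O` gives > 20000 nM in this assay, also a limit.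

Compound 1 differs from compound 2 by amino in place of hydrogen on an aromatic carbon. Because both values are limits, a step that the two limits leave unreadable from compound 2 to compound 1. Compound 3 shares no single counted difference with compound 2; the difference between the two cores is not broken down here. Compound 4 `Nc1nc2c(c(-c3cc4ccccc4o3)cn2[C@@H]2O[C@H](CO)[C@@H](O)[C@H]2O)c(=O)[nH]1` differs from compound 3 by amino in place of hydrogen on an aromatic carbon. This is the same kind of change as from compound 2 to compound 1, though the surroundings differ: in compound 1 the new amino sits meta to a methoxy group (2 heavy atoms), in compound 4 meta to a group of 1 heavy atom. Among the compounds with values here, since every value so far sits at the limit of > 20000 nM in this assay, at which 3 of the 3 values shown sit, the step that the limit leaves unreadable from compound 3 to compound 4 is expected to stay unreadable, and compound 4 is estimated at 30000 nM, expected between 15000 nM and 100000 nM.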

Compound 4, half-maximal inhibitory concentration: > 20000 nM
Compound 4: a limit, no number; the forecaster's own chance of this, stated with the estimate: 80%; the middle value lies beyond the limit too.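

Within the data shown here, compound 3 and compound 4 both sit at a limit, so no step between them can be read: the limit of > 20000 nM in this assay, at which 4 of the 4 values shown sit. The compounds shown leave open what amino in place of hydrogen does to inhibition.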